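Aryl thioether variation in an aminophenyl cinnamamide series

The source may hold more compounds than are shown below. What is called first, only, known or untested is meant among the compounds shown, and "the series" means these compounds.

Measured so far in a functional assay on HeLa cells (Homo sapiens) for inhibition, read by CCK-8 assay, with a stated time of 72 h, tested at 2 uM; a lower number here means less inhibition of growth, a higher number more inhibition of growth at the concentration tested:
compound 1, `Nc1ccccc1NC(=O)/C=C/c1ccc(CSc2ccc(Cl)cc2)cc1`: 1.94%
compound 2, `Cc1cc(C)cc(SCc2ccc(/C=C/C(=O)Nc3ccccc3N)cc2)c1`: 11.7%

Compound 2 gives the highest of the two numbers shown, but compound 1 lies within the scatter of it, so no real difference between the two is claimed. Compound 3, `CC(C)(C)c1ccc(SCc2ccc(/C=C/C(=O)Nc3ccccc3N)cc2)cc1`, carries 4-(tert-butyl)phenyl in place of 3,5-dimethylphenyl on a sulfur. Within the data shown here, the only measured step at this sulfur, a number 9.8 percentage points higher from compound 1 to compound 2 (within the scatter), is within the scatter, so a further exchange of the group on the sulfur is expected to give no step beyond the scatter in this assay. Compound 3 is estimated at 12%, range 0% to 28%, with a number 0.3 percentage points higher from compound 2 to compound 3 (within the scatter) expected.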

Compound 3, percent growth inhibition at one concentration: 17.5%
Beside the measured number, compound 3's estimate is 5.5 percentage points below it; low and high end bracket the measured number.
By their numbers in this assay, from the lowest: compounds 1, 2 and 3 (each within the scatter of the next, the first and the last beyond it).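

In this assay, the group on the sulfur gives its first step beyond the scatter, though a modest one (a number 15.6 percentage points higher from compound 1 to compound 3 (beyond the scatter)), with tert-butyl in place of chloro on an aromatic carbon. 4-(tert-butyl)phenyl in place of 3,5-dimethylphenyl stays within the scatter (a number 5.8 percentage points higher from compound 2 to compound 3 (within the scatter)), so these two groups are not separated. No available data account for the step beyond the scatter.

The aromatic groups shown carry only chloro, methyl or tert-butyl, so the effect of a carboxylic acid or an amine there remains open. From the compounds shown here alone, a plain butyl chain on the sulfur also remains open.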